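Aryl Methyl to Amide: Expectation for Compound 3

The compounds below may be only part of what the source reports. "The series", "measured", "known", "first", "only" and "open" are said of these compounds alone.

Compound 1 `COc1ccc(C)c(N2CCC(COc3cccc(C(CC(=O)O)C4CC4)c3)CC2)c1` gives 113% in a functional assay on cells for agonist activity at Free fatty acid receptor 1 (Homo sapiens), read by FLIPR and calcium flux, with a stated time of 60 min; a higher number here means a larger maximal response, a lower number a smaller maximal response. Compound 2 `COc1ccc(CN(C)CC(C)C)c(N2CCC(COc3cccc(C(CC(=O)O)C4CC4)c3)CC2)c1` gives 110%, and the step of a number 3 percentage points lower from compound 1 to compound 2 (within the scatter) lies within the scatter, so these two numbers cannot be ranked. Compound 3 `COc1ccc(C(=O)N(C)CC(C)(C)C)c(N2CCC(COc3cccc(C(CC(=O)O)C4CC4)c3)CC2)c1` differs from compound 1 by methyl(neopentyl)carbamoyl in place of methyl on an aromatic carbon. Among the compounds with values here, the single measured step alters a saturated chain carbon bound to an aromatic carbon, not the aromatic carbon changed here, and it stayed within the scatter, so no step bears directly on this change. No movement beyond the scatter is expected, meaning a number 3 percentage points lower from compound 1 to compound 3 (within the scatter). Compound 3 is estimated at 110%, within 92% to 125%.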

Compound 3, largest response reached (Emax), in percent of the reference or control that the assay uses: 107%
Estimate against measurement, compound 3: 3 percentage points above; measured number inside the range.
By their numbers in this assay, from the lowest: compounds 3, 2 and 1 (each within the scatter of the next).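

At this aromatic carbon, para to a methoxy group, methyl(neopentyl)carbamoyl with its 9 heavy atoms can replace the 1-atom methyl, and this assay shows only a number 6 percentage points lower from compound 1 to compound 3 (within the scatter). Replacing (isobutyl(methyl)amino)methyl with the same group gives a number 3 percentage points lower from compound 2 to compound 3 (within the scatter), so the maximal response does not separate these three substituents. No measurement here explains this tolerance. As far as these compounds go, whether a carboxylic acid or a small primary amide at this carbon would also keep the response remains open.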